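Swapping Dichlorophenyl for Dimethoxyphenyl on the Ketone Side

The source may hold more compounds than are shown below. What is called first, only, known or untested is meant among the compounds shown, and "the series" means these compounds.

Measured compounds:
Compound 1 `COc1ccc(-c2cc(/C=C/C(=O)c3ccc(OC)c(OC)c3)[nH]n2)cc1`: -55%
Compound 2 `COc1cc(-c2cc(/C=C/C(=O)c3ccc(Cl)c(Cl)c3)[nH]n2)cc(OC)c1OC`: -5%
Compound 3 `COc1ccc(-c2cc(/C=C/C(=O)c3ccc(N)cc3)[nH]n2)cc1OC`: -53%

In a functional assay on SW-620 cells (Homo sapiens) for cytotoxicity, read by sulforhodamine B assay, with a stated time of 48 h, tested at 100 uM (a higher number here means a weaker effect of the compound at the concentration tested, a lower number a stronger effect), compound 2 gives -5%, the highest number of the three, so the weakest effect in this set. Its nearest neighbour is compound 3, which in this assay gives -53%, a number beyond the scatter lower; furthest away is compound 1, which gives -55%, also beyond the scatter lower.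

Compound 4 `COc1ccc(C(=O)/C=C/c2cc(-c3cc(OC)c(OC)c(OC)c3)n[nH]2)cc1OC` has not yet been measured. It differs from compound 2 in one place: 3,4-dimethoxyphenyl in place of 3,4-dichlorophenyl on a carbonyl carbon. The 3,4-dimethoxyphenyl that enters is the same group found on the carbonyl carbon of compound 1, whose number in this assay sits far below that of compound 2. Going by the values given here, with no directly comparable step among the measured compounds, the expectation rests on that resemblance. Compound 4 is expected to give -40%, in a range from -70% to -5%. The step from compound 2 to compound 4 is thus estimated at a number 35 percentage points lower from compound 2 to compound 4 (beyond the scatter), a move toward stronger effect, beyond the scatter.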

Compound 4, a percentage reported as activity, at one concentration (the size of the read-out at that concentration, not a potency): -67%
Beside the measured number, compound 4's estimate is 27 percentage points above it, within the range that was stated.
By their numbers in this assay, from the lowest: compound 4; then compounds 1 and 3 (each within the scatter of the next); then compound 2.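

In this assay, going by these compounds alone, the exchange on the carbonyl carbon provides the first comparison in this set that differs in one place: 3,4-dimethoxyphenyl in place of 3,4-dichlorophenyl gives a number 62 percentage points lower from compound 2 to compound 4 (beyond the scatter) and so marks a large move toward stronger effect. This shows that the group on this carbonyl carbon can by itself change the read-out substantially while the rest of compound 2 stays unchanged. Nothing available here explains the size of this step.

From the compounds shown here alone, only these two groups can be compared at this place, so it remains open how a 3,4-difluorophenyl, a carboxylic acid or a morpholine would read there. The step also comes from a single tested concentration, leaving the potency of compound 2 and compound 4 undefined.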